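Two aldosterone synthase inhibitors and a third, not yet measured

A few compounds are considered here, and "the series" means these few. Any claim that something is new, unique, unknown or untested is made for them only; others in the source may bear on it.

Compound 1 `N#Cc1ccc(C2C(=O)N(Cc3ccccc3)Cc3cncn32)cc1` gives 40 nM in an assay on cells for inhibition of cytochrome P450 11B2, mitochondrial (Homo sapiens); on this read-out lower numbers stand for stronger inhibition and higher numbers for weaker inhibition. Compound 2 `C[C@@H](c1ccc(Cl)cc1)N1Cc2cncn2C(CC2(C)COC2)S1(=O)=O` gives 7.8 nM in this assay, the lower of the two numbers, with a gap to compound 1 that lies beyond the usual scatter. Compound 3 `C[C@@H](c1ccc(Cl)cc1)N1Cc2cncn2C(C[C@@H](O)c2ccccc2)S1(=O)=O` differs from compound 2 in one place: hydroxy(phenyl)methyl in place of 3-methyloxetan-3-yl on a saturated chain carbon bound to a saturated ring carbon. Among the measured compounds shown here, no measured pair shows this change, so only a rough expectation is possible. Compound 3 is expected to stay close to compound 2, with a step of a 1.5-fold higher number from compound 2 to compound 3 (0.19 log units; within the scatter) that need not exceed the scatter. For compound 3 the estimated value is 12 nM, expected to fall between 4 nM and 40 nM.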

Compound 3, half-maximal inhibitory concentration: 2.4 nM
Beside the measured number, compound 3's estimate is 5.0-fold (0.70 log units) above it; the whole stated range lies above it.
By their numbers in this assay, from the lowest: compound 3; then compound 2; then compound 1.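

On the saturated chain carbon bound to a saturated ring carbon, the change to hydroxy(phenyl)methyl brings a 3.3-fold lower number from compound 2 to compound 3 (0.51 log units; beyond the scatter) and so shows that this position accepts a larger group, with 8 heavy atoms in place of 5, without any loss of inhibition. The entering group also adds a six-membered aromatic ring and a hydrogen-bond donor. No available evidence explains the gain. The compounds shown leave open whether the hydroxy group or the phenyl ring carries this step, and how an amine in place of that hydroxy group, or a longer chain, would read out.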